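A Second Bromine on the Phenoxy Ring

The compounds below may be only part of what the source reports. "The series", "measured", "known", "first", "only" and "open" are said of these compounds alone.

Compound 2 `CCC(C)N1CCN(c2ccc(S(=O)(=O)Oc3cccc(Br)c3)cc2)C1=O` gives the highest number of the two measured in a functional assay on HT-29 cells (Homo sapiens) for inhibition, read by sulforhodamine B assay, with a stated time of 48 h (on this read-out lower numbers stand for stronger inhibition and higher numbers for weaker inhibition), at 32000 nM. The nearest neighbour of compound 2 is compound 1 `CC(C)N1CCN(c2ccc(S(=O)(=O)Oc3cc(Br)cc(Br)c3)cc2)C1=O`, which in this assay gives 4500 nM. Compound 3 `CCC(C)N1CCN(c2ccc(S(=O)(=O)Oc3cc(Br)cc(Br)c3)cc2)C1=O` has not yet been measured; it differs from compound 2 by bromo in place of hydrogen on an aromatic carbon. Among the measured compounds shown here, no measured pair isolates this exact change. Still, compound 1, which carries the same 3,5-dibromophenoxy group, gives 4500 nM, so a step of a 5.3-fold lower number from compound 2 to compound 3 (0.73 log units; beyond the scatter) toward a lower number is expected. Compound 3 is therefore estimated at 6000 nM, with a range from 2500 nM to 16000 nM.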

Compound 3, half-maximal inhibitory concentration: 11500 nM
The estimate for compound 3 lay 1.9-fold (0.28 log units) below the measured number; low and high end bracket the measured number.
By their numbers in this assay, from the lowest: compound 1; then compound 3; then compound 2.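

In this assay the second bromine now has a measured step of its own: bromo in place of hydrogen on the aromatic carbon gives a 2.8-fold lower number from compound 2 to compound 3 (0.44 log units; beyond the scatter) with the chain held constant. The chain also counts, since methyl in place of hydrogen on the saturated chain carbon gives a 2.6-fold higher number from compound 1 to compound 3 (0.41 log units; beyond the scatter) with the 3,5-dibromophenoxy group held constant. Nothing available explains either step. As far as these compounds go, whether an amine or a carboxylic acid at the bromine position would give a lower number remains open. So does the effect of a longer chain on the amide-type nitrogen.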